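Two limits, one unreadable step, and a smaller ring

A few compounds are considered here, and "the series" means these few. Any claim that something is new, unique, unknown or untested is made for them only; others in the source may bear on it.

Compound 1 `CC(C)[C@H](NC(=O)COc1cccc2ccccc12)C(=O)N[C@@H](CC(=O)O)C(=O)CSC1=NCCS1`: > 200000 nM
Compound 2 `CC(C)[C@H](NC(=O)COc1cccc2ccccc12)C(=O)N[C@@H](CC(=O)O)C(=O)CSc1nc(-c2ccccc2)cs1`: > 200000 nM

Both values come from a functional assay on Jurkat cells (Homo sapiens) for inhibition (on this read-out lower numbers stand for stronger inhibition and higher numbers for weaker inhibition), and both are limits of the assay rather than numbers. Compound 1 reaches only the limit > 200000 nM in this assay. Compound 2 likewise reaches only the limit > 200000 nM in this assay. The step that the two limits leave unreadable from compound 1 to compound 2 therefore cannot be read in size. Compound 2 stands at the limit, where every value shown sits, as the limit of > 200000 nM in this assay, at which 2 of the 2 values shown sit, records.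

Compound 3 `Cc1nnc(SCC(=O)[C@H](CC(=O)O)NC(=O)[C@@H](NC(=O)COc2cccc3ccccc23)C(C)C)s1` differs from compound 2 in one place: 5-methyl-1,3,4-thiadiazol-2-yl in place of 4-phenyl-1,3-thiazol-2-yl on a sulfur. No measured step bears on this change, and the only step shown gives no readable size. Nothing shown points to a number below the limit, so the step of a number no higher from compound 2 to compound 3 (the limit leaves the size open) is expected to be none beyond the scatter. Compound 3 is therefore estimated at 200000 nM, within 50000 nM to 400000 nM, and most likely reported again only as a limit.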

Compound 3, half-maximal inhibitory concentration: 190000 nM
Estimate against measurement, compound 3: 1.1-fold (0.02 log units) above; measured number inside the range.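

In this assay, going by these compounds alone, compound 3 gives 190000 nM, the first value here that is a number and not a limit of the assay. Placing 5-methyl-1,3,4-thiadiazol-2-yl on the sulfur gives an at least 1.0-fold lower number from compound 2 to compound 3 (0.02 log units; that floor lies within the scatter), and the same group gives an at least 1.0-fold lower number from compound 1 to compound 3 (0.02 log units; that floor lies within the scatter). Compound 1 and compound 2 are recorded only as limits, so these steps are floors whose true size stays open, and neither shows a change beyond the scatter: the limit of > 200000 nM in this assay, at which 2 of the 3 values shown sit.

On these data alone, whether a group of another kind on this sulfur, such as an amine, a carboxylic acid or a longer alkyl chain, would give a much lower number in this assay stays open. So does whether a change elsewhere on the shared core would matter more than one at this position.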